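A morpholin-4-yl step on a thiocarbonyl carbon

The source may hold more compounds than are shown below. What is called first, only, known or untested is meant among the compounds shown, and "the series" means these compounds.

In a functional assay on HCT-116 cells (Homo sapiens) for inhibition, read by CCK-8 assay, with a stated time of 48 h (a lower number here means a stronger inhibitor, a higher number a weaker inhibitor), compound 1 `COc1ccc(CN(C(=O)CSC(=S)N2CCN(C)CC2)c2cc(OC)c(OC)c(OC)c2)cc1` gives 2640 nM and stands second highest of three, with compound 2 `COc1ccc(CN(C(=O)CSC(=S)N2CCN(C(=O)OC(C)(C)C)CC2)c2cc(OC)c(OC)c(OC)c2)cc1` at 620 nM and compound 3 `COc1ccc(CN(C(=O)CSC(=S)N2CCN(Cc3ccc(C(C)(C)C)cc3)CC2)c2cc(OC)c(OC)c(OC)c2)cc1` at 6890 nM as the others. Compound 4 `COc1ccc(CN(C(=O)CSC(=S)N2CCOCC2)c2cc(OC)c(OC)c(OC)c2)cc1` carries morpholin-4-yl in place of 4-methylpiperazin-1-yl on a thiocarbonyl carbon. The measured steps all change the group on an amine nitrogen in a ring: a 4.3-fold lower number from compound 1 to compound 2 (0.63 log units; beyond the scatter) is modest, a 2.6-fold higher number from compound 1 to compound 3 (0.42 log units; beyond the scatter) is modest and runs the other way, and an 11-fold higher number from compound 2 to compound 3 (1.05 log units; beyond the scatter) is large. None replaces the ring itself, so in this assay a modest step or none beyond the scatter is expected. The slight lean to a lower number rests only on compound 2 at 620 nM and is weak. The estimated change is a 1.5-fold lower number from compound 1 to compound 4 (0.17 log units; within the scatter) in this reading. Compound 4 is expected at 1800 nM (from 650 nM to 5000 nM).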

Compound 4, half-maximal inhibitory concentration: 4130 nM
Estimate against measurement, compound 4: 2.3-fold (0.36 log units) below, within the range that was stated.
By their numbers in this assay, from the lowest: compound 2; then compounds 1, 4 and 3 (each within the scatter of the next, the first and the last beyond it).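

In this assay, among the compounds shown here, morpholin-4-yl in place of 4-methylpiperazin-1-yl on a thiocarbonyl carbon gives a 1.6-fold higher number from compound 1 to compound 4 (0.19 log units; within the scatter), the first step here that replaces the ring itself rather than the group on its amine nitrogen. In this pair, a ring oxygen can stand in place of the methyl-bearing nitrogen with no step beyond the scatter. Nothing available explains this result. On these data alone, whether a piperidin-1-yl or pyrrolidin-1-yl group on the thiocarbonyl carbon would also stay within the scatter of compound 1 remains open.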